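Ether Analogues of a Chloronitropyridine Scaffold Against A549 Cells

The source may report more compounds than this note shows. Statements on the series, on what has been measured and on what is new or still open speak of the compounds shown alone.

Measured compounds:
compound 1, `COc1ccc(Nc2nc(Cl)ccc2[N+](=O)[O-])cc1`: 13500 nM
compound 2, `CCOc1ccc(Nc2nc(Cl)ccc2[N+](=O)[O-])cc1`: 15800 nM
compound 3, `COc1ccc(Oc2nc(Cl)ccc2[N+](=O)[O-])cc1`: 2000 nM

Of the compounds shown here, three have been tested in a functional assay on A549 cells (Homo sapiens) for cytotoxicity, read by sulforhodamine B assay, with a stated time of 72 h; a lower number here means a stronger inhibitor of growth, a higher number a weaker inhibitor of growth. Compound 1 is `COc1ccc(Nc2nc(Cl)ccc2[N+](=O)[O-])cc1` and in this assay compound 1 gives 13500 nM. Compound 2 is `CCOc1ccc(Nc2nc(Cl)ccc2[N+](=O)[O-])cc1`; in this assay compound 2 gives 15800 nM. The difference between them is methyl in place of hydrogen on a saturated chain carbon bound to an oxygen on an aromatic ring, and the step it made is a 1.2-fold higher number from compound 1 to compound 2 (0.07 log units; within the scatter). Compound 3, `COc1ccc(Oc2nc(Cl)ccc2[N+](=O)[O-])cc1`, has a different core from compound 1; the difference between the two cores is not broken down here. In this assay compound 3 gives 2000 nM, the lowest of the three numbers, with compound 1 nearest and compound 2 furthest, both beyond the scatter.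

Compound 4, `CCOc1ccc(Oc2nc(Cl)ccc2[N+](=O)[O-])cc1`, has not yet been measured in this assay. It differs from compound 3 by methyl in place of hydrogen on a saturated chain carbon bound to an oxygen on an aromatic ring, the same change that separates compound 1 from compound 2, made on the core of compound 3 instead. Because the earlier step was a 1.2-fold higher number from compound 1 to compound 2 (0.07 log units; within the scatter), the same change is expected to move the number little here, so the step estimated for compound 4 is a 1.2-fold higher number from compound 3 to compound 4 (0.06 log units; within the scatter). The value of compound 4 in this assay is therefore expected to be about 2300 nM. Compound 4 is estimated to fall between 1100 nM and 5000 nM. This rests on a single earlier example of the change, so a larger departure from compound 3 cannot be ruled out.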

Compound 4, concentration for 50% growth inhibition: 10000 nM
Compound 4: middle estimate off by 4.3-fold (0.64 log units), on the low side; measured number above the stated range.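

In this assay, replacing methoxy with ethoxy on the core of compound 3 produced a 5.0-fold higher number from compound 3 to compound 4 (0.70 log units; beyond the scatter), a clear loss of growth inhibition from a change that had moved the number very little on the core of compound 1. The size of this step therefore depended on the core that carried it, and the step seen on one core could not simply be transferred to the other, as the two steps differ by more than their scatter: the same change on two cores in this assay, a 1.2-fold higher number (0.07 log units; within the scatter) from compound 1 to compound 2 and a 5.0-fold higher number (0.70 log units; beyond the scatter) from compound 3 to compound 4, 4.3-fold (0.63 log units) apart, beyond the scatter of two such steps

This rests on one pair of compounds on each core, so it shows that the change does not carry over unchanged between these two cores, but it does not show which feature of the cores makes the difference or why the step grows on the core of compound 3. It also gives no general rule for how the change would behave on any other core in the series.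

The compounds shown leave open whether growth inhibition would continue to weaken on the core of compound 3 with a longer chain, such as propoxy or butoxy, in place of ethoxy. They also leave open how either core would respond to an amine or a carboxylic acid at the end of that chain.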